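A few compounds are considered here, and "the series" means these few. Any claim that something is new, unique, unknown or untested is made for them only; others in the source may bear on it.

Compound 1 `O=c1oc2ccccc2c2nc3c(ccc4cc[nH]c43)c(-c3cccc(Br)c3)c12`: 70700 nM
Compound 2 `O=c1oc2ccccc2c2nc3c(ccc4cc[nH]c43)c(-c3ccccn3)c12`: 70700 nM
Compound 3 `O=c1oc2ccccc2c2nc3c(ccc4cc[nH]c43)c(-c3ccc([N+](=O)[O-])cc3)c12`: 70700 nM

In a functional assay on B16-F10 cells (Mus musculus) for cytotoxicity (a lower number here means a stronger inhibitor, a higher number a weaker inhibitor), compound 3 gives 70700 nM, level with compound 1 and compound 2 at the digits shown. Compound 4 `O=c1oc2ccccc2c2nc3c(ccc4cc[nH]c43)c(-c3ccc(Cl)cc3)c12` keeps the shared core and differs from compound 3 in one group: chloro in place of nitro on an aromatic carbon. Put simply, the 4-nitrophenyl group of compound 3 becomes 4-chlorophenyl in compound 4. Three measured steps exchange that whole aromatic group: no change at the digits printed from compound 1 to compound 2 (within the scatter), no change at the digits printed from compound 1 to compound 3 (within the scatter) and no change at the digits printed from compound 2 to compound 3 (within the scatter). All three lie within the scatter, so no step beyond the scatter is expected here. The expected step is no change at the digits printed from compound 3 to compound 4 (within the scatter). For compound 4 the estimated value is 70700 nM, with an expected range of 35000 nM to 100000 nM.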

Compound 4, half-maximal inhibitory concentration: 70700 nM
Estimate against measurement, compound 4: no gap at the digits printed, and the stated range covers the measured number.
By their numbers in this assay, from the lowest: compounds 1, 2, 3 and 4 (each within the scatter of the next).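

In this assay, exchanging only the substituent on the phenyl ring, with the ring itself kept, gives no change at the digits printed from compound 3 to compound 4 (within the scatter). Against the other aromatic groups, 4-chlorophenyl gives no change at the digits printed from compound 2 to compound 4 (within the scatter) and no change at the digits printed from compound 1 to compound 4 (within the scatter). A chloro group therefore joins nitro, the 3-bromophenyl group and pyridin-2-yl with the same printed number, and this holds for all four compounds. From the compounds shown here alone, whether an amine or a carboxylic acid on this ring, or an open alkyl chain in place of it, would give a different number stays open. No measurement at hand offers a reason for this sameness.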